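The source may report more compounds than this note shows. Statements on the series, on what has been measured and on what is new or still open speak of the compounds shown alone.

The study concerns a series of benzoxazole sulfonamides tested in an assay on cells for inhibition of HSP60/HSP10 (Homo sapiens), with a stated time of 60 min; a higher number here means a weaker inhibitor, a lower number a stronger inhibitor. Compound 1 `O=S(=O)(Nc1ccc2oc(-c3ccccc3)nc2c1)c1ccc(Cl)cc1` carries a 4-chlorophenyl on the sulfonyl sulfur. In this assay compound 1 gives > 100000 nM, which is a limit of the assay and not a number. Compound 2 `Cc1cccc(S(=O)(=O)Nc2ccc3oc(-c4ccccc4)nc3c2)c1` carries a 3-methylphenyl in that position. In this assay compound 2 gives > 100000 nM, again a limit rather than a number. Compound 3 `Cc1cccc(S(=O)(=O)Nc2ccc(-c3nc4ccccc4o3)cc2)c1` is built from the same atoms as compound 2, joined differently, and the difference between the two cores is not broken down here. In this assay compound 3 gives > 100000 nM, which is likewise a limit.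

The change from compound 2 to compound 1 is 4-chlorophenyl in place of 3-methylphenyl on a sulfonyl sulfur. The step it made, a step that the two limits leave unreadable from compound 2 to compound 1, cannot be read because the limit of > 100000 nM in this assay, at which 3 of the 3 values shown sit, holds both of its ends.

Compound 4 `O=S(=O)(Nc1ccc(-c2nc3ccccc3o2)cc1)c1ccc(Cl)cc1` has not yet been measured. Among the measured compounds shown here, it differs from compound 3 by 4-chlorophenyl in place of 3-methylphenyl on a sulfonyl sulfur, which is the same change, made at the same place, as the one from compound 2 to compound 1. Because the limit of > 100000 nM in this assay, at which 3 of the 3 values shown sit, holds all three measured compounds, compound 4 is expected to give 150000 nM in this assay, with an expected range from 50000 nM to 500000 nM, and most probably only a limit will be reported again. The step this estimate implies, a step that the limit leaves unreadable from compound 3 to compound 4, is accordingly expected to be small.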

Compound 4, half-maximal inhibitory concentration: 61000 nM
Compound 4: middle estimate off by 2.5-fold (0.39 log units), on the high side, within the range that was stated.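

On the core of compound 3, 4-chlorophenyl in place of 3-methylphenyl on a sulfonyl sulfur gives an at least 1.6-fold lower number from compound 3 to compound 4 (0.21 log units; that floor lies within the scatter). This shows that the change, carried to this core, yields a compound with a measured number: in this assay compound 4 gives 61000 nM. The size of the step is known only as a floor and does not establish an effect beyond the usual scatter. It does not show whether the change does the same on both cores, because the step from compound 2 to compound 1 cannot be read, both of its ends sitting at the limit: the limit of > 100000 nM in this assay, at which 3 of the 4 values shown sit.

The compounds shown leave open how far the step from compound 3 to compound 4 really reaches, as well as whether the same change on the core of compound 2 gives any readable step at all. They also leave open how an amine, a carboxylic acid or a longer alkyl chain in place of the 4-chlorophenyl on a sulfonyl sulfur would read in this assay, on either core.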